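A few compounds are considered here, and "the series" means these few. Any claim that something is new, unique, unknown or untested is made for them only; others in the source may bear on it.

Compound 1 `COc1cccc(/C=C/C(=O)C(=Cc2ccc(O)c(F)c2)C(=O)/C=C/c2cccc(OC)c2OC)c1OC` and compound 3 `COc1ccc(OC)c(/C=C/C(=O)C(=Cc2ccc(O)c(F)c2)C(=O)/C=C/c2cc(OC)ccc2OC)c1` are built from the same atoms joined differently; how the two cores differ is not broken down here. In a functional assay on CNE-2 cells (Homo sapiens) for antiproliferative activity, read by sulforhodamine B assay, with a stated time of 48 h (a lower number here means a stronger inhibitor, a higher number a weaker inhibitor), compound 1 gives 260 nM, and compound 3 gives 380 nM, so the two numbers lie close together. Compound 2 `COc1cc(C=C(C(=O)/C=C/c2cccc(OC)c2OC)C(=O)/C=C/c2cccc(OC)c2OC)cc(OC)c1O` differs from compound 1 in one place only: 4-hydroxy-3,5-dimethoxyphenyl in place of 3-fluoro-4-hydroxyphenyl on a double-bonded chain carbon bound to a double-bonded chain carbon. In this assay compound 2 gives 300 nM, which amounts to a 1.2-fold higher number from compound 1 to compound 2 (0.06 log units; within the scatter). Compound 4 `COc1ccc(OC)c(/C=C/C(=O)C(=Cc2cc(OC)c(O)c(OC)c2)C(=O)/C=C/c2cc(OC)ccc2OC)c1` has not yet been measured; it differs from compound 3 by the same change, (4-hydroxy-3,5-dimethoxyphenyl in place of 3-fluoro-4-hydroxyphenyl on a double-bonded chain carbon bound to a double-bonded chain carbon), made at the same place as in the earlier pair, so it is the same kind of change on a different core. Going by the values given here, because the one measured example of this change gave a 1.2-fold higher number from compound 1 to compound 2 (0.06 log units; within the scatter), a step of about the same small size is expected in this assay, namely a 1.2-fold higher number from compound 3 to compound 4 (0.07 log units; within the scatter), and this rests on that single pair alone. The estimate for compound 4 in this assay is therefore 450 nM, with a likely range from 250 nM to 800 nM.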

Compound 4, half-maximal inhibitory concentration: 450 nM
Compound 4: middle estimate and measured number agree at the digits printed, within the range that was stated.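

On the core of compound 3, putting 4-hydroxy-3,5-dimethoxyphenyl in place of 3-fluoro-4-hydroxyphenyl gives in this assay a 1.2-fold higher number from compound 3 to compound 4 (0.07 log units; within the scatter), so the swap makes no difference that can be told from ordinary measurement noise. Set beside the earlier pair, the two steps match: the same change on two cores in this assay, a 1.2-fold higher number (0.06 log units; within the scatter) from compound 1 to compound 2 and a 1.2-fold higher number (0.07 log units; within the scatter) from compound 3 to compound 4, 1.0-fold (0.01 log units) apart, within the scatter of two such steps

This shows that, on these two cores, the swap behaves alike and is tolerated in this assay, but both steps are too small to show a real direction, so neither group can be called better, and two cores say nothing firm about other cores in the series. The match also concerns a swap with almost no measurable effect, which is a weaker test of transfer than a large step repeating on a second core would be.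

Both groups shown at this place are phenyl rings carrying a hydroxy group, so it remains open what a quite different substituent there, such as an amine or a carboxylic acid, would do to the number. Going by these compounds, whether the same swap stays this quiet in other cell lines also remains open.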